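Swapping Benzyl for 3-Chlorophenyl on an Amide-Type Nitrogen

The source may report more compounds than this note shows. Statements on the series, on what has been measured and on what is new or still open speak of the compounds shown alone.

Going by the values given here, compound 1 `S=C(NCc1ccccc1)N/N=C/c1ccc2ccccc2n1` is the only compound here with a measured number: in a functional assay on HeLa cells (Homo sapiens) for antiproliferative activity, read by sulforhodamine B assay, with a stated time of 72 h (a lower number here means a stronger inhibitor, a higher number a weaker inhibitor), compound 1 gives 62800 nM. Compound 2 `Cc1ccc(NC(=O)N/N=C/c2ccc3ccccc3n2)cc1` reaches only a limit of this assay, > 100000 nM, which is not a number. Compound 3 `S=C(N/N=C/c1ccc2ccccc2n1)Nc1cccc(Cl)c1` differs from compound 1 in one place: 3-chlorophenyl in place of benzyl on an amide-type nitrogen. Among the compounds with values here, no step between two measured compounds is known, so nothing tells the direction of this change; a step no larger than the usual scatter is expected, with weaker activity about as likely as stronger. Compound 3 is estimated to give about 45000 nM, within a range from 9000 nM to 150000 nM, an expected step of a 1.4-fold lower number from compound 1 to compound 3 (0.14 log units; within the scatter).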

Compound 3, half-maximal inhibitory concentration: 52500 nM
Beside the measured number, compound 3's estimate is 1.2-fold (0.07 log units) below it; low and high end bracket the measured number.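

Going by these compounds alone, exchanging benzyl for 3-chlorophenyl on the amide-type nitrogen gives a 1.2-fold lower number from compound 1 to compound 3 (0.08 log units; within the scatter) in this assay, the first step that can be read at this position. Within the scatter, the two groups cannot be told apart here, although they differ in their atoms. Nothing shown explains this outcome.

Still open, from the compounds shown here alone, is how an unsubstituted phenyl compares, which would separate the part played by the chlorine from that of the ring. Also open, going by these compounds, is whether a carboxylic acid, an amine or a longer chain here would shift the number beyond the scatter.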